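A dimethylamino swap in a series at the assay limit

A few compounds are considered here, and "the series" means these few. Any claim that something is new, unique, unknown or untested is made for them only; others in the source may bear on it.

Compound 1 `CCC1=C(C(=O)OCC2CCCCC2)C(c2ccc(O)cc2)NC(=O)N1` gives > 10000 nM (a limit)
Compound 2 `CCC1=C(C(=O)OCC2CCCCC2)C(c2cccc(N)c2)NC(=O)N1` gives > 10000 nM (a limit)
Compound 3 `CCC1=C(C(=O)OCC2CCCCC2)C(c2ccc(NC(C)=O)cc2)NC(=O)N1` gives > 10000 nM (a limit)

In an ADME assay on CEMx174 cells (Homo sapiens) for cytotoxicity (a lower number here means that less compound is tolerated, a higher number that more compound is tolerated), compound 3 gives > 10000 nM as a limit and not as a number. The whole set rests on (the limit of > 10000 nM in this assay, at which 3 of the 3 values shown sit), so no exact value is available yet. Compound 4 `CCC1=C(C(=O)OCC2CCCCC2)C(c2ccc(N(C)C)cc2)NC(=O)N1` has dimethylamino in place of acetamido on an aromatic carbon. Within the data shown here, two measured steps also swap a group on the aromatic ring, and with a step that the two limits leave unreadable from compound 1 to compound 2 and a step that the two limits leave unreadable from compound 1 to compound 3 no compound leaves the limit, so no change beyond the scatter is expected in this assay here. This expectation amounts to an estimated step that the limit leaves unreadable from compound 3 to compound 4 overall. For compound 4 the expected value is 20000 nM, with an estimated range from 8000 nM to 60000 nM, and the assay will probably report only a limit.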

Compound 4, half-maximal cytotoxic concentration: > 10000 nM
Compound 4 gave a limit, no number; the forecaster's own chance of this, stated with the estimate: 85%; the middle value is on the limit's open side.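

In this assay compound 4 gives the limit > 10000 nM and no number, so its steps from compound 1, compound 2 and compound 3 cannot be read: the limit of > 10000 nM in this assay, at which 4 of the 4 values shown sit.

The compounds shown leave open what concentration of any of them harms these cells, and whether the swapped groups differ at all.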